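This account rests on a few compounds, and the source may have more. Where it says the series, first, only, none or still open, it means among the compounds named here.

Working notes on the amide series. Compound 1 `Cc1ccccc1C(=O)Nc1cccc(-c2oc3cc(-c4ccc(F)cc4)ccc3c(=O)c2O)c1` gives 4910 nM in a functional assay on MDA-MB-231 cells (Homo sapiens) for antiproliferative activity, read by CCK-8 assay, with a stated time of 72 h; a lower number here means a stronger inhibitor, a higher number a weaker inhibitor. Among the measured compounds shown here, compound 2 `COc1ccc(C(=O)Nc2cccc(-c3oc4cc(-c5ccc(F)cc5)ccc4c(=O)c3O)c2)c(F)c1` gives 17600 nM in this assay, the higher of the two numbers measured so far; the only step recorded is a 3.6-fold higher number from compound 1 to compound 2 (0.55 log units; beyond the scatter), a change of the aryl group on the carbonyl carbon.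

Compound 3 `O=C(Nc1cccc(-c2oc3cc(-c4ccc(F)cc4)ccc3c(=O)c2O)c1)c1cc(F)cc(F)c1` has not been measured. It differs from compound 2 as follows: 3,5-difluorophenyl in place of 2-fluoro-4-methoxyphenyl on a carbonyl carbon. For the measured compounds named here, no measured pair repeats this exact change, so the one step that bears on it is the aryl exchange from compound 1 to compound 2, which moved the number by a modest amount beyond the scatter. Both measured aryl groups give weak inhibition; a third aryl variation of the same kind is not expected to move far, and the loss of the methoxy-bearing group may bring compound 3 back toward compound 1 rather than further out. In this assay compound 3 is therefore expected to show a 2.2-fold lower number from compound 2 to compound 3 (0.34 log units; beyond the scatter), a modest step toward a lower number. The estimate for compound 3 in this assay is 8000 nM, with a range from 3000 nM to 25000 nM.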

Compound 3, half-maximal inhibitory concentration: 2440 nM
For compound 3 the middle estimate is 3.3-fold (0.52 log units) above the measured one; measured number outside the range, below it.
By their numbers in this assay, from the lowest: compounds 3 and 1 (each within the scatter of the next); then compound 2.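

Working from this assay, on the carbonyl carbon whose other neighbour is the amide-type nitrogen, 3,5-difluorophenyl in place of 2-fluoro-4-methoxyphenyl gives a 7.2-fold lower number from compound 2 to compound 3 (0.86 log units; beyond the scatter), which runs in the opposite direction to the only earlier step, a 3.6-fold higher number from compound 1 to compound 2 (0.55 log units; beyond the scatter). 3,5-Difluorophenyl in place of 2-methylphenyl gives a 2.0-fold lower number from compound 1 to compound 3 (0.30 log units; within the scatter), so two of the three aryl groups sit level and only 2-fluoro-4-methoxyphenyl stands apart, with the higher number. Compound 2 and compound 3 both carry fluorine on this ring, so the presence of fluorine does not by itself sort the three compounds.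

From the compounds shown here alone, the step from compound 2 to compound 3 changes the methoxy group and the fluorine pattern together, so their separate contributions stay open, as does the reading at this carbonyl carbon of a phenyl ring bearing an amine or a carboxylic acid, or of a longer alkyl chain in place of the ring. Nothing in hand gives a measured reason for the size or direction of these steps.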